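A few compounds are considered here, and "the series" means these few. Any claim that something is new, unique, unknown or untested is made for them only; others in the source may bear on it.

In an ADME assay on HEK293 cells (Homo sapiens) for cytotoxicity, read by MTT assay, with a stated time of 48 h (a lower number here means a stronger inhibitor, a higher number a weaker inhibitor), compound 2 `COc1ccc(/C=C2/S/C(=N/c3ccccc3)N(Cc3ccncc3)C2=O)cc1` gives 47900 nM, which lies within the scatter of compound 1 `O=C1/C(=C\c2ccccc2)S/C(=N/c2ccccc2)N1Cc1ccncc1` at 64700 nM. Compound 3 `O=C1/C(=C\c2ccc([N+](=O)[O-])cc2)S/C(=N/c2ccccc2)N1Cc1ccncc1` has nitro in place of methoxy on an aromatic carbon, para to a large group (nitro in place of methoxy on an aromatic carbon). Among the compounds with values here, the only measured step on this aromatic carbon is a 1.4-fold lower number from compound 1 to compound 2 (0.13 log units; within the scatter). It gives no direction for nitro, so no change beyond the scatter is expected in this assay. The expected step is a 1.2-fold lower number from compound 2 to compound 3 (0.08 log units; within the scatter). Compound 3 is estimated at 40000 nM, with an expected range of 15000 nM to 100000 nM.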

Compound 3, half-maximal inhibitory concentration: 250000 nM
Compound 3: middle estimate off by 6.3-fold (0.80 log units), on the low side; measured number above the stated range.
By their numbers in this assay, from the lowest: compounds 2 and 1 (each within the scatter of the next); then compound 3.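

Nitro on this aromatic carbon gives a 5.2-fold higher number from compound 2 to compound 3 (0.72 log units; beyond the scatter) and a 3.9-fold higher number from compound 1 to compound 3 (0.59 log units; beyond the scatter) in this assay. Both steps lie beyond the scatter, so this position can register a change of group, which the step from hydrogen to methoxy did not show. Nothing available explains the rise.

Within the data shown here, whether the rise is particular to nitro stays open, as the only groups compared here are hydrogen, methoxy and nitro. An amine or a carboxylic acid on this carbon would show whether other groups shift the number as well.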